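Aryl swap on the piperazine: 2-methylphenyl replaces 3-fluorophenyl

A few compounds are considered here, and "the series" means these few. Any claim that something is new, unique, unknown or untested is made for them only; others in the source may bear on it.

Measured compounds:
- compound 1, `CCCc1nc(-c2ccccc2)c(CNCCN2CCN(c3ccc(F)cc3)CC2)o1`, 7080 nM
- compound 2, `CCCc1nc(-c2ccccc2)c(CNCCN2CCN(c3cccc(F)c3)CC2)o1`, 3350 nM

Compound 2 gives the lowest number of the two in an assay on HEK293 cells for inhibition of Voltage-dependent T-type calcium channel subunit alpha-1G (Homo sapiens), read by patch clamp; a lower number here means a stronger inhibitor, a higher number a weaker inhibitor; its nearest neighbour is compound 1, which sits a 2.1-fold lower number from compound 1 to compound 2 (0.32 log units; beyond the scatter) step above it. For the measured compounds named here, that one step, 3-fluorophenyl in place of 4-fluorophenyl on an amine nitrogen in a ring, is the only change seen so far, and it was modest.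

Compound 3, `CCCc1nc(-c2ccccc2)c(CNCCN2CCN(c3ccccc3C)CC2)o1`, keeps everything of compound 2 except the aryl group on the ring nitrogen: 2-methylphenyl in place of 3-fluorophenyl on an amine nitrogen in a ring. Going by the values given here, no measured step covers a methyl on this aryl group, nor the place it now takes; the single measured step from compound 1 to compound 2 shows only that changing the substituent on this ring moves the number by a modest amount. The expectation is therefore a step of similar or smaller size, with no firm direction, estimated as a 1.2-fold higher number from compound 2 to compound 3 (0.08 log units; within the scatter) in this assay. Compound 3 is estimated at 4000 nM, with a range from 1500 nM to 11000 nM.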

Compound 3, half-maximal inhibitory concentration: 4300 nM
Beside the measured number, compound 3's estimate is 1.1-fold (0.03 log units) below it, and the stated range covers the measured number.
By their numbers in this assay, from the lowest: compounds 2, 3 and 1 (each within the scatter of the next, the first and the last beyond it).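

In this assay, the move to 2-methylphenyl gives a 1.3-fold higher number from compound 2 to compound 3 (0.11 log units; within the scatter) and a 1.6-fold lower number from compound 1 to compound 3 (0.22 log units; within the scatter), so compound 3 cannot be told apart from either fluorine-bearing compound. The aryl group on this ring nitrogen therefore accepts a methyl in place of a fluorine, with the substituent also in a different place on the aryl group, without a step beyond the scatter, even though compound 1 and compound 2 do differ by more than the scatter. Nothing here offers a measured reason for this result.

On these data alone, since the group and its place on the aryl group change together, the effect of each alone remains unknown: a 2-fluorophenyl or a 3-methylphenyl on the same nitrogen would separate the two. As far as these compounds go, how a plain phenyl, or a larger group such as 2-methoxyphenyl, would compare also stays open, as does whether any aryl group here can bring the number well below those of these three compounds.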